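Shared core: 4-nitrophenyl to 4-methylphenyl on the sulfonyl

The compounds below may be only part of what the source reports. "The series", "measured", "known", "first", "only" and "open" are said of these compounds alone.

Measured in a functional assay on MGC-803 cells (Homo sapiens) for cytotoxicity, read by MTT assay, with a stated time of 48 h; on this read-out lower numbers stand for stronger inhibition and higher numbers for weaker inhibition:
- compound 1 `O=C(c1ccccc1)N1N=C(c2cc3ccccc3oc2=O)CC1c1ccccc1`: 12700 nM
- compound 2 `O=c1oc2ccccc2cc1C1=NN(S(=O)(=O)c2ccc([N+](=O)[O-])cc2)C(c2ccccc2)C1`: 41200 nM

For the measured compounds named here, compound 2 stands at the highest of the two numbers known so far; compound 1 sits at the lower number, and the gap between the two is beyond the scatter. Going by the values given here, the two compounds differ in more than one place, so no single step between them can be read off.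

Compound 3 `Cc1ccc(S(=O)(=O)N2N=C(c3cc4ccccc4oc3=O)CC2c2ccccc2)cc1` is the next entry. It differs from compound 2 in one place: methyl in place of nitro on an aromatic carbon.

Among the compounds with values here, no measured pair shows this change, so the size of the step is open. In this assay the expectation for compound 3 is a modest step toward a lower number, of a size that may not clear the scatter, and compound 3 is estimated at 25000 nM, with a range from 8000 nM to 80000 nM. The step this estimate implies is a 1.6-fold lower number from compound 2 to compound 3 (0.22 log units; within the scatter).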

Compound 3, half-maximal inhibitory concentration: 50200 nM
Compound 3: the middle estimate sits 2.0-fold (0.30 log units) below what was measured, and the stated range covers the measured number.
By their numbers in this assay, from the lowest: compound 1; then compounds 2 and 3 (each within the scatter of the next).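

In this assay, the change from 4-nitrophenyl to 4-methylphenyl on the sulfonyl gives a 1.2-fold higher number from compound 2 to compound 3 (0.09 log units; within the scatter) and so separates neither compound, even though the hydrogen-bond acceptors of nitro are lost at this carbon. For the compounds shown here, the step at the ring amine nitrogen, with (4-methylphenyl)sulfonyl in place of benzoyl, gives a 4.0-fold higher number from compound 1 to compound 3 (0.60 log units; beyond the scatter) and is the only one of these two steps that lies beyond the scatter. Nothing measured here gives a cause for either step.

On these data alone, whether this position stays equally insensitive to other groups, such as an amine, a carboxylic acid or a methoxy group, remains open. Also open, as far as these compounds go, is whether the step at the ring nitrogen would hold with a different aryl group on the sulfonyl.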